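Moving the fluorine: compound 2 to compound 3

The compounds below may be only part of what the source reports. "The series", "measured", "known", "first", "only" and "open" are said of these compounds alone.

Within the data shown here, in an ADME assay on MT2 cells (Homo sapiens) for cytotoxicity, read by XTT assay, with a stated time of 4 days (a higher number here means that more compound is tolerated, a lower number that less compound is tolerated), compound 1, `Cc1ccc(NC(=O)C(=O)NC(c2nc(C)c(CCO)s2)C2CCCCN2)cc1F`, gives 85000 nM, the only true number so far. As far as these compounds go, compound 2, `Cc1ccc(NC(=O)C(=O)NC(c2nc(C)c(CO)s2)C2CCCCN2)c(F)c1`, returns only a limit in this assay, > 109000 nM, so its exact position is unknown. Compound 3, `Cc1ccc(NC(=O)C(=O)NC(c2nc(C)c(CO)s2)C2CCCCN2)cc1F`, awaits measurement. Its change from compound 2 is 3-fluoro-4-methylphenyl in place of 2-fluoro-4-methylphenyl on an amide-type nitrogen, with the same atoms joined differently. Among the measured compounds shown here, no measured pair isolates this swap, so any forecast remains loose. In this assay, no shift beyond the usual scatter is expected, and the estimated change is an at least 1.1-fold lower number from compound 2 to compound 3 (0.05 log units; that floor lies within the scatter). This expectation leans on compound 1 at 85000 nM, which keeps the forecast in the same high range. The estimate for compound 3 is 95000 nM, expected to fall within 50000 nM to 180000 nM.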

Compound 3, half-maximal cytotoxic concentration: > 88000 nM
Compound 3 gave a limit, no number; the forecaster's own chance of this, stated with the estimate: 45%; the middle value lies beyond the limit too.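

Compound 3 also returns only a limit, not a number, in this assay: the limit of > 88000 nM in this assay, at which 1 of the 3 values shown sits.

Compound 2 is likewise held at a limit, so the step for 3-fluoro-4-methylphenyl in place of 2-fluoro-4-methylphenyl on an amide-type nitrogen cannot be read, and this swap still has no measured size. Among these compounds, the one readable comparison is for hydroxy in place of hydroxymethyl on a saturated chain carbon bound to an aromatic carbon, which gives an at least 1.0-fold higher number from compound 1 to compound 3 (0.01 log units; that floor lies within the scatter), so it establishes no difference beyond the scatter.

As far as these compounds go, whether the place of the fluorine matters at all in this assay stays open until compound 2 and compound 3 have true numbers. From the compounds shown here alone, how a carboxylic acid or an amine in place of the hydroxymethyl would read there also stays open.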